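Chloro in Place of Hydrogen: Compound 2 to Compound 4

The compounds below may be only part of what the source reports. "The series", "measured", "known", "first", "only" and "open" are said of these compounds alone.

Measured compounds:
Compound 1 `Cc1cc(OCc2ccccc2)c2nc(C)c(C)n2c1` gives 0% in a functional assay on the whole organism with Canis familiaris (Canis lupus familiaris) as the target, at a dose of 4 mg/kg by the oral route; on this read-out higher numbers stand for a stronger effect at the one dose given and lower numbers for a weaker effect.
Compound 2 `Cc1nc2c(OCc3ccccc3)cccn2c1N` gives 74% in this assay.
Compound 3 `Cc1nc2c(OCc3ccccc3F)cccn2c1N` gives 46% in this assay.

Compound 2 stands highest of the three numbers in this assay; compound 3 lies nearest to it and compound 1 furthest, both steps beyond the scatter. Compound 4 `Cc1nc2c(OCc3ccc(Cl)cc3)cccn2c1N` has not yet been tested. It differs from compound 2 in one place: chloro in place of hydrogen on an aromatic carbon.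

Among the measured compounds shown here, only one measured step bears on this change, the step in which fluoro replaced hydrogen on an aromatic carbon: a number 28 percentage points lower from compound 2 to compound 3 (beyond the scatter). That step involved a halogen on the same ring and was modest. For the measured compounds named here, because of a number 28 percentage points lower from compound 2 to compound 3 (beyond the scatter), a decrease of similar size is expected for compound 4, though the single precedent leaves the size uncertain. The expected step is a number 19 percentage points lower from compound 2 to compound 4 (beyond the scatter). Compound 4 is therefore estimated to give 55% in this assay, with a range from 30% to 78%.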

Compound 4, a percentage reported as inhibition, in the whole organism at one dose (the size of the read-out at that dose, not a potency): 81%
Compound 4: middle estimate off by 26 percentage points, on the low side; the measured number lies above the stated range.
By their numbers in this assay, from the lowest: compound 1; then compound 3; then compounds 2 and 4 (each within the scatter of the next).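

In this assay, chloro in place of hydrogen on an aromatic carbon, para to a large group, gives a number 7 percentage points higher from compound 2 to compound 4 (within the scatter), so this position accepts a chloro group with no change that can be read beyond the scatter. The earlier fluoro step, a number 28 percentage points lower from compound 2 to compound 3 (beyond the scatter), therefore does not describe every halogen on this ring, and compound 3 is the compound that goes against any rule that a halogen there lowers the number. Nothing shown accounts for the difference between these two halogen steps.

Going by these compounds, whether other groups at this carbon, such as methoxy, trifluoromethyl or an amine, would also leave the number unchanged remains open. On these data alone, it is also open how chloro would behave on the carbon that bears fluoro in compound 3.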